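Chloro for Hydroxy in a Quinolone Series: Cytotoxicity

The source may report more compounds than this note shows. Statements on the series, on what has been measured and on what is new or still open speak of the compounds shown alone.

Measured compounds:
- compound 1 `CCOC(=O)c1c(-c2cccc(Cl)c2)[nH]c2cc(OC)ccc2c1=O`: > 22000 nM
- compound 2 `CCOC(=O)c1c(-c2cccc(O)c2)[nH]c2cc(OC)ccc2c1=O`: > 22000 nM
- compound 3 `CCOC(=O)c1c(-c2cccc(-c3ccccc3)c2)[nH]c2cc(O)ccc2c1=O`: > 22000 nM

Of the compounds shown here, three have been tested in an ADME assay on HEK293 cells (Homo sapiens) for cytotoxicity, read by luminescence, with a stated time of 72 h; a higher number here means that more compound is needed for the effect, a lower number that less compound is needed. In this assay compound 1 gives > 22000 nM, which is a limit of the assay rather than a number. Compound 2 likewise gives > 22000 nM, again a limit. Compound 3 gives > 22000 nM, also a limit. All three values therefore sit at the same boundary, as summarised by the limit of > 22000 nM in this assay, at which 3 of the 3 values shown sit.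

Compound 2 and compound 1 differ in one place: chloro in place of hydroxy on an aromatic carbon. The step that the two limits leave unreadable from compound 2 to compound 1 cannot be sized, because both ends are limits.

Compound 4 `CCOC(=O)c1c(-c2cccc(-c3ccccc3)c2)[nH]c2cc(Cl)ccc2c1=O` is not yet measured. It is made from compound 3 by chloro in place of hydroxy on an aromatic carbon. For the measured compounds named here, this is the same kind of change as the one from compound 2 to compound 1, but the surroundings differ: in compound 1 the place is on a six-membered aromatic ring of carbon only, meta to a large group, while in compound 4 it is part of a fused or bridged system of two rings, meta to a fused ring and para to a fused ring. How the core of compound 3 differs from the core of compound 2 is not broken down here.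

Because every measured value sits at the limit of > 22000 nM in this assay, at which 3 of the 3 values shown sit, compound 4 is expected to stay at that boundary as well. The expected step that the limit leaves unreadable from compound 3 to compound 4 is therefore near zero, and compound 4 is estimated at 30000 nM, with a range from 15000 nM to 90000 nM.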

Compound 4, half-maximal effective concentration: > 22000 nM
Compound 4: a limit, no number; the forecaster's own chance of this, stated with the estimate: 85%; the middle value lies beyond the limit too.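

Compound 3 and compound 4 both end at a limit of the assay, so no size can be read for the change from hydroxy to chloro. All four compounds sit at the same boundary: the limit of > 22000 nM in this assay, at which 4 of the 4 values shown sit.

What they leave open is the concentration at which any of them would give the effect in this assay, and whether chloro in place of hydroxy shifts it at all.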